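A Fluorine Added to Compound 1: What to Expect

This account rests on a few compounds, and the source may have more. Where it says the series, first, only, none or still open, it means among the compounds named here.

Compound 1, with structure `C[C@]1(CO)OC[C@@H](n2ccc(N)nc2=O)O1`, was tested in a functional assay on B16-F10 cells (Mus musculus) for inhibition (on this read-out lower numbers stand for stronger inhibition and higher numbers for weaker inhibition), and gave 100000 nM. Compound 2, drawn as `CC1(CO)OCC(n2ccc(N)nc2=O)O1`, has the same atoms and bonds, and in this assay compound 2 gives 100000 nM. The step of no change at the digits printed from compound 1 to compound 2 (within the scatter) is flat, which fits the point that the two drawings differ only in whether a configuration is shown, as the fact that one of compounds 1 and 2 is drawn with a defined configuration and the other without, at the place where they differ records. Compound 1 therefore stands level with compound 2 at a weak reading, and these numbers give no way to tell the two apart.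

Compound 3, `C[C@]1(CO)OC[C@@H](n2cc(F)c(N)nc2=O)O1`, differs from compound 1 by fluoro in place of hydrogen on an aromatic carbon. Within the data shown here, no measured step touches that ring, so the only step available, the flat one from compound 1 to compound 2, says nothing about what a fluoro adds there. The expected step of a 1.3-fold lower number from compound 1 to compound 3 (0.10 log units; within the scatter) is therefore set at none beyond the scatter, with a wide range to allow for the untested change. Compound 3 is expected to give 80000 nM in this assay, within 15000 nM to 100000 nM.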

Compound 3, half-maximal inhibitory concentration: > 100000 nM
Compound 3: only a limit was reported (the forecaster's own chance of this, stated with the estimate: 50%); at least 1.2-fold (0.09 log units) between middle value and limit.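

Among these compounds, the first change to the six-membered aromatic ring with 2 nitrogen, fluoro in place of hydrogen on an aromatic carbon ortho to the amino group, gives a number no lower from compound 1 to compound 3 (the limit leaves the size open). In this assay compound 3 gives > 100000 nM, which is a limit of the assay and not a number. So this single fluorine at this position brings no lower number, and how far it moves the reading cannot be told, because the result is only a limit: the limit of > 100000 nM in this assay, at which 1 of the 3 values shown sits.

The compounds shown leave open whether a different group at this same position, such as a chlorine atom or a methyl group, would give a lower number than hydrogen or fluoro do. They also leave open whether a change elsewhere on the core of compound 1, such as a carboxylic acid in place of the hydroxymethyl group, would bring the reading into a range where steps can be sized.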